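A Benzyl Swap on the Piperidine Nitrogen

A few compounds are considered here, and "the series" means these few. Any claim that something is new, unique, unknown or untested is made for them only; others in the source may bear on it.

Three related compounds have been tested in a functional assay on HepG2 cells (Homo sapiens) for cytotoxicity, read by MTT assay, with a stated time of 72 h; a higher number here means a weaker inhibitor, a lower number a stronger inhibitor. Compound 1 `O=C(COc1ccc(-c2cc(=O)c3ccccc3o2)cc1)NC1CCN(Cc2ccccc2)CC1` gives 15500 nM and compound 2 `CC(C)(Oc1ccc2c(=O)cc(-c3ccccc3)oc2c1)C(=O)NC1CCN(Cc2ccccc2)CC1` gives 14000 nM. Going by the values given here, compound 3 `O=C(COc1ccc2c(=O)cc(-c3ccccc3)oc2c1)NC1CCN(C(=O)c2ccccc2)CC1` yields no number in this assay, only the limit > 20000 nM, so it is the one compound of the three sitting at the limit of > 20000 nM in this assay, at which 1 of the 3 values shown sits, and its true value is unknown.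

Compound 4 `O=C(COc1ccc2c(=O)cc(-c3ccccc3)oc2c1)NC1CCN(Cc2ccccc2)CC1` differs from compound 3 in one place: benzyl in place of benzoyl on an amine nitrogen in a ring. Since compound 3 has only a limit, the size of this step cannot be read from a measured pair, and compounds 1 and 2 carry the benzyl group with values near each other. The change from compound 3 to compound 4 is expected to give a step of an at least 1.2-fold lower number from compound 3 to compound 4 (0.09 log units; that floor lies within the scatter) toward stronger inhibition, though it could fall within scatter. Compound 4 is therefore estimated at 16000 nM, between 6000 nM and 40000 nM.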

Compound 4, half-maximal inhibitory concentration: 16700 nM
The estimate for compound 4 lay 1.0-fold (0.02 log units) below the measured number; the measured number falls inside the stated range.
By their numbers in this assay, from the lowest: compounds 2, 1 and 4 (each within the scatter of the next). At a limit, above all of these: compound 3.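

Going by these compounds alone, with benzyl in place of benzoyl on the amine nitrogen in the ring, this assay gives an at least 1.1-fold lower number from compound 3 to compound 4 (0.07 log units; that floor lies within the scatter), the first step at this position on an otherwise unchanged structure. On these data alone, compound 4 therefore gives a real number, while the size of the change remains unknown, because compound 3 gives only a limit: the limit of > 20000 nM in this assay, at which 1 of the 4 values shown sits.

The step shows only a floor, so even its direction is not firmly settled. As far as these compounds go, how a methyl or an acetyl group on this nitrogen, or a free amine, would read in this assay remains open.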